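The source may hold more compounds than are shown below. What is called first, only, known or untested is meant among the compounds shown, and "the series" means these compounds.

Compound 1 (`CC(C)(CO)Nc1nc(N)nc2c1ncn2[C@H]1C[C@H](N=[N+]=[N-])[C@@H](CO)O1`) carries a (1-(hydroxymethyl)-1-methylethyl)amino group on the shared core. In an ADME assay on CCRF-CEM cells (Homo sapiens) for cytotoxicity, with a stated time of 5 days (on this read-out lower numbers stand for stronger inhibition and higher numbers for weaker inhibition), compound 1 gives > 100000 nM as its reading, which is a limit of the assay and not a number. Compound 2 (`COc1nc(F)nc2c1ncn2[C@H]1C[C@H](N=[N+]=[N-])[C@@H](CO)O1`) gives > 100000 nM as its reading, again a limit. Compound 3 (`COc1nc(Cl)nc2c1ncn2[C@H]1C[C@H](N=[N+]=[N-])[C@@H](CO)O1`) gives > 100000 nM as its reading, likewise a limit. Compound 1 therefore has no numerical place among the three, and all of them share the limit of > 100000 nM in this assay, at which 3 of the 3 values shown sit, as their common position.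

Compound 4 (`C=CCN(C)c1nc(N)nc2c1ncn2[C@H]1C[C@H](N=[N+]=[N-])[C@@H](CO)O1`) has not yet been measured. It has allyl(methyl)amino in place of (1-(hydroxymethyl)-1-methylethyl)amino on an aromatic carbon. Among the measured compounds shown here, the only measured step on hand is a step that the two limits leave unreadable from compound 2 to compound 3 and it concerns chloro in place of fluoro on an aromatic carbon, a different change that offers no size to carry over.

Because the limit of > 100000 nM in this assay, at which 3 of the 3 values shown sit, covers compound 1 and the two others, no step beyond the usual scatter can be foreseen in this assay in either direction. The expected outcome is a number no higher from compound 1 to compound 4 (the limit leaves the size open) as an estimate with no clear direction. For compound 4 the estimated value is 100000 nM with an expected range from 30000 nM to 200000 nM and a reading that may well be only a limit.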

Compound 4, half-maximal inhibitory concentration: 27000 nM
The estimate for compound 4 lay 3.7-fold (0.57 log units) above the measured number; the measured number lies below the stated range.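

In this assay, putting allyl(methyl)amino in place of (1-(hydroxymethyl)-1-methylethyl)amino on this aromatic carbon gives an at least 3.7-fold lower number from compound 1 to compound 4 (0.56 log units; beyond the scatter), which shows that a change at this position can bring the reading within the range where a number is obtained. The only earlier step, between the fluoro and chloro compounds, cannot be read, so this is the first measured sign that a substituent on the shared core matters here, and compound 4 alone among those shown has a reading that is a number: the limit of > 100000 nM in this assay, at which 3 of the 4 values shown sit. The change swaps a group with 2 hydrogen-bond donors and a hydroxymethyl unit for one with 0 hydrogen-bond donors and 1 double bond outside aromatic rings, and this single step cannot separate these differences from one another.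

The compounds shown leave open whether the double bond matters, which a saturated propyl(methyl)amino group at the same position would test, and whether the methyl on the nitrogen matters, which a plain allylamino group would test. They also leave open whether a ring amine such as pyrrolidine or piperidine at this position would lower the number further or return the reading to the limit.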